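The source may hold more compounds than are shown below. What is called first, only, known or untested is meant among the compounds shown, and "the series" means these compounds.

Compound 1, with the structure `CCOc1ccc2oc(/C=C/[S+](C)[O-])cc(=O)c2c1`, gives 1500 nM in a functional assay on A549 cells (Homo sapiens) for cytotoxicity, with a stated time of 48 h; a lower number here means a stronger inhibitor, a higher number a weaker inhibitor. Its companion compound 2, with the structure `CCCCCOc1ccc2oc(/C=C/[S+](C)[O-])cc(=O)c2c1`, gives 1600 nM in this assay, and the step of a 1.1-fold higher number from compound 1 to compound 2 (0.03 log units; within the scatter) shows that lengthening the chain on the ring oxygen leaves the number essentially where it was. Going by the values given here, compound 1 therefore stands lowest of the two numbers measured so far, but its neighbour compound 2 sits within the scatter of it, so the two cannot be told apart.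

The next compound, compound 3, has the structure `Cc1ccc2oc(/C=C/[S+](C)[O-])cc(=O)c2c1`. Compared with compound 1 it shows the change (methyl in place of ethoxy on an aromatic carbon). Among the compounds with values here, the only measured step, that from compound 1 to compound 2, alters the chain on the oxygen but keeps the oxygen, so it speaks to the present change only indirectly; it suggests that this part of the core tolerates variation without a large shift. Within the data shown here, no measured step removes the ring oxygen itself, so a moderate movement in either direction cannot be excluded. The expected step of a 1.3-fold higher number from compound 1 to compound 3 (0.12 log units; within the scatter) is therefore small, with compound 3 estimated at 2000 nM, in the range 800 nM to 5000 nM.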

Compound 3, half-maximal inhibitory concentration: 1700 nM
Beside the measured number, compound 3's estimate is 1.2-fold (0.07 log units) above it; measured number inside the range.
By their numbers in this assay, from the lowest: compounds 1, 2 and 3 (each within the scatter of the next).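

In this assay the step from ethoxy to methyl on this aromatic carbon (a 1.1-fold higher number from compound 1 to compound 3 (0.05 log units; within the scatter)) and the step from pentyloxy to methyl on the same carbon (a 1.1-fold higher number from compound 2 to compound 3 (0.03 log units; within the scatter)) both stay within the scatter. Compounds 1 and 2 varied only the chain on the oxygen, whereas compound 3 loses the oxygen as well, so this position now keeps its number without that oxygen and its hydrogen-bond acceptor, and with a single heavy atom in place of the three of ethoxy. No measurement at hand explains why the three numbers stay together.

The compounds shown leave open whether this carbon tolerates any group at all, as all three carry a carbon or oxygen substituent there, and bare hydrogen, a chlorine, an amine or a carboxylic acid at this carbon would test how far the flat picture extends. They also keep the rest of the shared core and the side chain bearing the sulfur unchanged, so nothing here says whether those parts are as forgiving as this aromatic carbon.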